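The source may hold more compounds than are shown below. What is called first, only, known or untested is meant among the compounds shown, and "the series" means these compounds.

Compound 1, `Ic1ccccc1-c1ncco1`, and compound 2, `O=[N+]([O-])c1ccccc1-c1ncco1`, share one core. In a physicochemical assay for lipophilicity (on this read-out higher numbers stand for higher lipophilicity and lower numbers for lower lipophilicity), compound 1 gives 2.3, while compound 2 gives 1.27. Among the measured compounds shown here, the single change between them, (nitro in place of iodo on an aromatic carbon), produced a number 1.03 log units lower from compound 1 to compound 2 (beyond the scatter). Compound 3, `Ic1ccccc1C1=NC(c2ccccc2)CO1`, is built on a different core, and the difference between the two cores is not broken down here. In this assay compound 3 gives 3.86. Compound 4, `O=[N+]([O-])c1ccccc1C1=NC(c2ccccc2)CO1`, arises from compound 3 by the same kind of change, (nitro in place of iodo on an aromatic carbon); in compound 3 the place is described as ortho to a large group, whereas in compound 1 it is ortho to a group of 5 heavy atoms. Because a number 1.03 log units lower from compound 1 to compound 2 (beyond the scatter) followed this change once already, a step of similar size is expected, namely a number 1.03 log units lower from compound 3 to compound 4 (beyond the scatter). Compound 4 is therefore estimated at 2.83, most likely between 2.4 and 3.3.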

Compound 4, partition coefficient: 2.83
Beside the measured number, compound 4's estimate shows no gap at the digits printed, within the range that was stated.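

Nitro in place of iodo on an aromatic carbon gave a number 1.03 log units lower from compound 3 to compound 4 (beyond the scatter) in this assay and on the other core the same change gave a number 1.03 log units lower from compound 1 to compound 2 (beyond the scatter) so the step carried over from one core to the other at the same size. Among the compounds shown here, this rests on only two pairs of compounds on two cores, so it shows agreement for these compounds and not a rule that would hold on every core. Nothing measured here explains why the two steps agree.

The compounds shown leave open whether an amine, a carboxylic acid or a longer chain in place of iodo would also give matching steps on these two cores. They also leave open whether nitro in place of iodo would give a step of this size on a third core.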